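From 4-fluorobenzyl to 4-methylbenzyl in a cell assay

The source may hold more compounds than are shown below. What is called first, only, known or untested is meant among the compounds shown, and "the series" means these compounds.

In a functional assay on A549 cells (Homo sapiens) for inhibition, read by MTT assay, with a stated time of 48 h (on this read-out higher numbers stand for weaker inhibition and lower numbers for stronger inhibition), compound 1 `COc1ccc2c(=O)c(/C=C/C(=O)NCc3ccccc3)coc2c1` gives 11800 nM as a measured number. Compound 2 `COc1ccc2c(=O)c(/C=C/C(=O)NCc3ccc(F)cc3)coc2c1` gives > 100000 nM and this is a limit, not a number. Compound 3 `O=C(/C=C/c1coc2cc(O)ccc2c1=O)NCc1ccc(F)cc1` gives > 100000 nM and this too is a limit, so it stands at the limit of > 100000 nM in this assay, at which 2 of the 3 values shown sit, with no exact value. The step with hydrogen in place of methyl on an oxygen is a step that the two limits leave unreadable from compound 2 to compound 3 and tells us little.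

Compound 4 `Cc1ccc(CNC(=O)/C=C/c2coc3cc(O)ccc3c2=O)cc1` changes one group of compound 3 (methyl in place of fluoro on an aromatic carbon): methyl in place of fluoro on an aromatic carbon, turning 4-fluorobenzyl into 4-methylbenzyl. Within the data shown here, the only readable guide is the arrival of fluoro in compound 2, which showed an at least 8.4-fold higher number from compound 1 to compound 2 (0.92 log units; beyond the scatter) in this series. Removing fluoro might therefore lower the number, but methyl is not hydrogen, so only a partial recovery is expected. The expected change is an at least 1.4-fold lower number from compound 3 to compound 4 (0.15 log units; that floor lies within the scatter) and it is uncertain in size. Compound 4 is estimated at 70000 nM with an expected range from 20000 nM to 200000 nM and it may also return only a limit.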

Compound 4, half-maximal inhibitory concentration: 17400 nM
For compound 4 the middle estimate is 4.0-fold (0.60 log units) above the measured one, outside the stated range (below it).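

Fluoro at this place on the ring is not a neutral feature in this assay: exchanging that one heavy atom for the one carbon of methyl gives an at least 5.7-fold lower number from compound 3 to compound 4 (0.75 log units; beyond the scatter). With an at least 8.4-fold higher number from compound 1 to compound 2 (0.92 log units; beyond the scatter), this makes two readable steps in which fluoro carries the higher number, one against hydrogen and one against methyl, with no step shown going the other way. The size of the new step is only a floor because the value of compound 3 is a limit: the limit of > 100000 nM in this assay, at which 2 of the 4 values shown sit.

The compounds shown leave open whether methyl itself lowers the number or whether losing fluoro is enough, and whether methyl would do the same on the methoxy core of compound 2. They also cannot say how chloro, a longer chain such as ethyl, or an amine would behave at this place.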